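The source may report more compounds than this note shows. Statements on the series, on what has been measured and on what is new or still open speak of the compounds shown alone.

Measured so far in a physicochemical assay for solubility, in phosphate buffer, with a stated time of 24 h, at pH 7.4, tested at 100 uM; a lower number here means a less soluble compound, a higher number a more soluble compound

compound 1 `O=C(NCc1ccc(S(=O)(=O)c2cncc(C(F)(F)F)c2)cc1)N1Cc2ccncc2C1` gives 83000 nM
compound 2 `O=C(NCc1ccc(S(=O)(=O)c2cc(F)cc(F)c2)cc1)N1Cc2ccncc2C1` gives 16000 nM

Compound 2 holds the lower of the two numbers. Compound 3 `CCCn1cc(S(=O)(=O)c2ccc(CNC(=O)N3Cc4ccncc4C3)cc2)cn1` differs from it by 1-propyl-1H-pyrazol-4-yl in place of 3,5-difluorophenyl on a sulfonyl sulfur in one place: 1-propyl-1H-pyrazol-4-yl in place of 3,5-difluorophenyl on a sulfonyl sulfur. Among the compounds with values here, one measured step bears on this: a 5.2-fold lower number from compound 1 to compound 2 (0.71 log units; beyond the scatter) with 3,5-difluorophenyl entering, modest and beyond the scatter. Within the data shown here, no measured compound carries the entering group, so the evidence is thin. With 3,5-difluorophenyl leaving, a modest rise is expected in this assay with a 2.5-fold higher number from compound 2 to compound 3 (0.40 log units; beyond the scatter) as the expected step. The estimate for compound 3 is 40000 nM within a range of 13000 nM to 95000 nM for this read-out.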

Compound 3, solubility: 105000 nM
Estimate against measurement, compound 3: 2.6-fold (0.42 log units) below; measured number above the stated range.
By their numbers in this assay, from the lowest: compound 2; then compounds 1 and 3 (each within the scatter of the next).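

In this assay, replacing 3,5-difluorophenyl on the sulfonyl sulfur with 1-propyl-1H-pyrazol-4-yl gives a clear rise (a 6.6-fold higher number from compound 2 to compound 3 (0.82 log units; beyond the scatter)). The five-membered aromatic ring with 2 hetero atoms and the six-membered ring of compound 1 cannot be separated (a 1.3-fold higher number from compound 1 to compound 3 (0.10 log units; within the scatter)). Of these three compounds, only compound 2 lacks ring nitrogen in this group, and it holds the lowest number, but no measurement explains the gap.

On these data alone, the part played by the propyl chain stays open. So does the outcome with a methyl group, an amine or a carboxylic acid on the pyrazole.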